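The source may report more compounds than this note shows. Statements on the series, on what has been measured and on what is new or still open speak of the compounds shown alone.

Working notes on the series. Compound 3 `CC1CC(=O)N(C(C)C(=O)NCc2ccccc2)C1=O` is one of two compounds with a number in a functional assay on the whole organism (strain Albino Swiss CD1) with Mus musculus as the target, in the maximal electroshock model; on this read-out higher numbers stand for an effect only at larger amounts of compound and lower numbers for an effect already at smaller amounts; compound 3 gives 106 mg/kg. Compound 1 `CCC(C(=O)NCc1ccccc1Cl)N1C(=O)CCC1=O` gives 113 mg/kg in this assay, and the two numbers lie within the scatter of each other, so no order between compound 3 and compound 1 can be read from them. Compound 2 `CCC(C(=O)NCc1ccccc1F)N1C(=O)CCC1=O` has no result in this assay, recorded as "not determined" (no result reported).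

Compound 4 `CC1CC(=O)N(C(C)C(=O)NCc2cccc(Cl)c2)C1=O` is obtained from compound 3 by the change (chloro in place of hydrogen on an aromatic carbon), that is, chloro in place of hydrogen on an aromatic carbon, meta to a large group. Going by the values given here, no pair of measured compounds shows this change on the shared core, so no measured step can be quoted for it. Compound 1 carries a chloro on its ring and compound 3 carries none, but their cores differ as well, so the two values show only that both fall in the same region.

The step from compound 3 to compound 4 is therefore expected to be small, a 1.1-fold lower number from compound 3 to compound 4 (0.05 log units; within the scatter), not beyond the scatter in either direction. Compound 4 is estimated at 95 mg/kg, with a range from 45 mg/kg to 200 mg/kg.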

Compound 4, dose for half-maximal effect: 90.3 mg/kg
Compound 4: the middle estimate sits 1.1-fold (0.02 log units) above what was measured; low and high end bracket the measured number.
By their numbers in this assay, from the lowest: compounds 4, 3 and 1 (each within the scatter of the next).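

In this assay, chloro in place of hydrogen on an aromatic carbon, meta to a large group, now has a measured step on the shared core: a 1.2-fold lower number from compound 3 to compound 4 (0.07 log units; within the scatter). The earlier comparison of compound 1 and compound 3 mixed a ring chloro with a difference in core, whereas this pair isolates the change and shows that phenyl to 3-chlorophenyl at this position leaves the read-out within the scatter. Nothing on hand gives a reason for the size of this step.

On these data alone, it remains open whether an amine, a carboxylic acid or a methoxy group in the same place would also stay within the scatter. As far as these compounds go, it is also open whether the same chloro step would hold on the core of compound 1.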